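Cytotoxicity notes on a small four-compound series

This account rests on a few compounds, and the source may have more. Where it says the series, first, only, none or still open, it means among the compounds named here.

In a toxicity assay on A549 cells (Homo sapiens) for cytotoxicity, read by luminescence and CellTiter-Glo, with a stated time of 48 h (a higher number here means that more compound is tolerated, a lower number that less compound is tolerated), the measured compounds stand as follows:

compound 1, `CCCCOc1ccc(-c2nc3ncccn3c2N)cc1` — > 100000 nM.
compound 2, `CCCCOc1ccc(-c2c(NC(C)(C)CC(C)(C)C)nc3ncccn23)cc1` — 49000 nM.
compound 3, `Nc1c(-c2ccc(Br)cc2)nc2ncccn12` — > 100000 nM.

For compound 1 the value in this assay is a limit of the assay, not a number. For compound 3 the value is likewise a limit. Among the measured compounds shown here, compound 2 is the only compound with a number; the other two values are limits, as given by the limit of > 100000 nM in this assay, at which 2 of the 3 values shown sit. The change from compound 1 to compound 3 is bromo in place of butoxy on an aromatic carbon; its step that the two limits leave unreadable from compound 1 to compound 3 cannot be read, since both ends sit at the limit.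

Compound 4, `CC(C)(C)CC(C)(C)Nc1nc2ncccn2c1-c1ccc(Br)cc1`, is not yet measured. It differs from compound 2 by bromo in place of butoxy on an aromatic carbon, the same change as from compound 1 to compound 3, at a place described in identical words. How the core of compound 2 differs from the core of compound 1 is not broken down here.

For the measured compounds named here, since the only measured instance of this change is unreadable, the expectation for compound 4 rests on compound 2 alone, with 49000 nM as the anchor. The step from compound 2 to compound 4 is expected to be small, a 1.1-fold higher number from compound 2 to compound 4 (0.05 log units; within the scatter), and compound 4 is estimated at 55000 nM, between 20000 nM and 150000 nM, with a fair chance that only a limit is reported.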

Compound 4, half-maximal cytotoxic concentration: > 100000 nM
Compound 4 ended at the assay's limit; the forecaster's own chance of this, stated with the estimate: 35%; middle value at least 1.8-fold (0.25 log units) from the limit.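

In this assay, as far as these compounds go, bromo in place of butoxy on an aromatic carbon gives an at least 2.0-fold higher number from compound 2 to compound 4 (0.30 log units; that floor lies within the scatter), and this is only a floor, so the true size of the step stays unknown. Compound 4 gives > 100000 nM, which is a limit of the assay and not a number. The same change on the core of compound 1 cannot be read, so the two cores offer no pair of sizes to compare, and the notes neither confirm nor refute that the change carries from one core to the other, with most of the series resting at one boundary: the limit of > 100000 nM in this assay, at which 3 of the 4 values shown sit.

From the compounds shown here alone, only butoxy and bromo appear at this place on the aromatic ring, so it remains open whether a shorter chain such as ethoxy, a longer chain such as octyloxy, an amine or a carboxylic acid there would give a readable number on either core. Also open, going by these compounds, is whether a smaller alkyl group on the ring nitrogen substituent position of compound 2, which gives 49000 nM, would keep a value that can be read at all.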